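Chain extension on the methoxy compound

The compounds below may be only part of what the source reports. "The series", "measured", "known", "first", "only" and "open" are said of these compounds alone.

Among the compounds with values here, in a functional assay on SW480 cells (Homo sapiens) for antiproliferative activity, read by MTT assay, with a stated time of 48 h (on this read-out lower numbers stand for stronger inhibition and higher numbers for weaker inhibition), compound 2 `CCCCCCCCC(CCO)n1cnc2c(OC)ncnc21` gives 24600 nM, the highest of the two numbers so far, and compound 1 `CCCCCCCCC(CCO)n1cnc2c(Cl)ncnc21` gives 1370 nM. Compound 3 `CCCCCCCCCCCC(CCO)n1cnc2c(OC)ncnc21` keeps the methoxy group of compound 2 and differs from it by propyl in place of hydrogen on a saturated chain carbon, nine bonds along the chain from an aromatic nitrogen. Within the data shown here, the only measured step, an 18-fold higher number from compound 1 to compound 2 (1.25 log units; beyond the scatter), is large, but it is methoxy in place of chloro on an aromatic carbon, not a change in the chain. No chain change has been measured, so no step beyond the scatter is expected in this assay. The expected step, within the scatter, is a 1.5-fold lower number from compound 2 to compound 3 (0.19 log units; within the scatter). For compound 3 the estimate is 16000 nM, with an expected range of 5000 nM to 45000 nM.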

Compound 3, half-maximal inhibitory concentration: 9700 nM
Compound 3: middle estimate off by 1.6-fold (0.22 log units), on the high side, within the range that was stated.
By their numbers in this assay, from the lowest: compound 1; then compound 3; then compound 2.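

In this assay, within the data shown here, the chain site responds on its own: propyl in place of hydrogen on a saturated chain carbon, nine bonds along the chain from an aromatic nitrogen, gives a 2.5-fold lower number from compound 2 to compound 3 (0.40 log units; beyond the scatter) and is the first chain step. The methoxy series therefore moves with the chain as well as with the aromatic substituent, although this modest step is smaller than the large 18-fold higher number from compound 1 to compound 2 (1.25 log units; beyond the scatter) on the aromatic carbon. Nothing among the available data accounts for the chain step.

From the compounds shown here alone, whether the same propyl change would move compound 1 to a similar extent remains open, since the chain step is known only with methoxy. A single step also gives no trend, and a longer chain than that of compound 3 would show whether the direction continues.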